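The source may hold more compounds than are shown below. What is called first, only, known or untested is meant among the compounds shown, and "the series" means these compounds.

Of the compounds shown here, three built on one shared core have been measured so far, and a fourth awaits measurement. Compound 1 `Cc1ccc2[nH]c(=O)c(-c3nc4cc([N+](=O)[O-])ccc4[nH]3)cc2c1` carries a methyl group and a nitro group on its two ends. In a functional assay on NCI-H460 cells (Homo sapiens) for cytotoxicity, read by MTT assay, with a stated time of 48 h (a higher number here means a weaker inhibitor, a lower number a stronger inhibitor), compound 1 gives > 100000 nM, which is a limit of the assay rather than a number. Compound 2 `COc1ccc2[nH]c(=O)c(-c3nc4cc([N+](=O)[O-])ccc4[nH]3)cc2c1` differs from compound 1 by methoxy in place of methyl on an aromatic carbon. In this assay compound 2 gives > 100000 nM, again only a limit. The step that the two limits leave unreadable from compound 1 to compound 2 therefore cannot be sized. Compound 3 `Cc1ccc2[nH]c(=O)c(-c3nc4cc(Br)ccc4[nH]3)cc2c1` differs from compound 1 by bromo in place of nitro on an aromatic carbon, which is how the core of compound 3 differs from the core of compound 1. In this assay compound 3 gives > 100000 nM, once more a limit. The step that the two limits leave unreadable from compound 1 to compound 3 is likewise unreadable. All of this rests on (the limit of > 100000 nM in this assay, at which 3 of the 3 values shown sit), so none of the three compounds can be ranked against the others.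

Compound 4 `COc1ccc2[nH]c(=O)c(-c3nc4cc(Br)ccc4[nH]3)cc2c1` is the one not yet measured. It differs from compound 3 by methoxy in place of methyl on an aromatic carbon. The surroundings of the changed position are described in exactly the same words as for the change from compound 1 to compound 2, so this is the same change made on the core of compound 3. The step is expected to be a step that the limit leaves unreadable from compound 3 to compound 4, because the matching step that the two limits leave unreadable from compound 1 to compound 2 left both of its ends at the limit. Compound 4 is therefore estimated at 150000 nM, with a range from 40000 nM to 600000 nM, and most likely the assay will again report only a limit.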

Compound 4, half-maximal inhibitory concentration: > 100000 nM
Compound 4 was reported as a limit; the forecaster's own chance of this, stated with the estimate: 85%; the middle value lies beyond the limit too.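

In this assay compound 4 gives > 100000 nM, which is again a limit of the assay and not a number. The steps from compound 3 and from compound 2 to compound 4 therefore cannot be read: the limit of > 100000 nM in this assay, at which 4 of the 4 values shown sit. The compounds shown leave open whether swapping methyl for methoxy, or nitro for bromo, changes the result in this assay at all, and how compound 1, compound 2, compound 3 and compound 4 rank against one another.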